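Swapping the aryl group on a bicyclic glutamate analogue

The source may hold more compounds than are shown below. What is called first, only, known or untested is meant among the compounds shown, and "the series" means these compounds.

Measured so far:
Compound 1 `N#Cc1cccc(CO[C@@H]2C[C@@H]3[C@H]([C@]2(N)C(=O)O)[C@@]3(F)C(=O)O)c1` — 2.94 nM
Compound 2 `N[C@]1(C(=O)O)[C@H]2[C@@H](C[C@H]1OCc1cc(F)ccc1F)[C@]2(F)C(=O)O` — 14.4 nM

In an assay on CHO cells for binding affinity to metabotropic glutamate receptor 2 (Rattus norvegicus) (a higher number here means a weaker inhibitor, a lower number a stronger inhibitor), compound 2 shows the highest number of the two, with compound 1 at 2.94 nM. For the measured compounds named here, the one measured step, a 4.9-fold higher number from compound 1 to compound 2 (0.69 log units; beyond the scatter), came from changing the aryl group alone. Compound 3 `N[C@]1(C(=O)O)[C@H]2[C@@H](C[C@H]1OCc1cc(Cl)cc(Cl)c1)[C@]2(F)C(=O)O` makes a change at the same place: 3,5-dichlorophenyl in place of 2,5-difluorophenyl on a saturated chain carbon bound to an oxygen on a saturated carbon. Going by the values given here, with only that one step to go on, the direction is uncertain; a move back toward compound 1 is plausible. Compound 3 is therefore expected to give 6 nM (range 2 nM to 20 nM), an expected step of a 2.4-fold lower number from compound 2 to compound 3 (0.38 log units; beyond the scatter).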

Compound 3, inhibition constant: 5.61 nM
Compound 3: middle estimate off by 1.1-fold (0.03 log units), on the high side, within the range that was stated.
By their numbers in this assay, from the lowest: compounds 1 and 3 (each within the scatter of the next); then compound 2.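

In this assay the aryl group at this place can win back what the first swap lost: 3,5-dichlorophenyl gives a 2.6-fold lower number from compound 2 to compound 3 (0.41 log units; beyond the scatter) and draws level with 3-cyanophenyl, with a 1.9-fold higher number from compound 1 to compound 3 (0.28 log units; within the scatter) between them. A nitrile is thus not needed to reach this level among these three compounds. Nothing measured here accounts for either step. The change swaps fluorine for chlorine and moves the halogens at once, so the compounds shown leave open which of the two matters. From the compounds shown here alone, how a carboxylic acid or an aminomethyl group on the phenyl ring would fare also stays open.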